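Swapping Isopentyloxy for Heptyl on the Shared Core

The source may report more compounds than this note shows. Statements on the series, on what has been measured and on what is new or still open speak of the compounds shown alone.

In a functional assay on brain (Rattus norvegicus, strain Wistar) for inhibition (a higher number here means a weaker inhibitor, a lower number a stronger inhibitor), compound 3 `Cc1[nH]c(=O)n(C)c1-c1ccc(OCCC(C)C)cc1` gives 6600 nM. This lies within the scatter of compound 1 `CCCCOc1ccc(-c2c(C)[nH]c(=O)n2C)cc1` at 5100 nM, and well away from compound 2 `COc1ccc(-c2c(C)[nH]c(=O)n2C)cc1` at 147000 nM. Compound 4 `CCCCCCCc1ccc(-c2c(C)[nH]c(=O)n2C)cc1` carries heptyl in place of isopentyloxy on an aromatic carbon. Among the measured compounds, chain length matters most: the short chain gives large steps, a 29-fold higher number from compound 1 to compound 2 (1.46 log units; beyond the scatter) and a 22-fold lower number from compound 2 to compound 3 (1.35 log units; beyond the scatter), while branching the longer chain gives little, a 1.3-fold higher number from compound 1 to compound 3 (0.11 log units; within the scatter). Among the compounds with values here, no measured step removes the oxygen, so this swap remains untested. Compound 4 keeps a long chain, so no step beyond the scatter is expected, and the estimated step is a 1.5-fold lower number from compound 3 to compound 4 (0.17 log units; within the scatter). For compound 4 the expected value is 4500 nM, with an estimated range of 1400 nM to 15000 nM.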

Compound 4, half-maximal inhibitory concentration: 8400 nM
Beside the measured number, compound 4's estimate is 1.9-fold (0.27 log units) below it; the measured number falls inside the stated range.
By their numbers in this assay, from the lowest: compounds 1, 3 and 4 (each within the scatter of the next); then compound 2.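

In this assay, this aromatic carbon does not need an oxygen to carry a long chain: heptyl has no hydrogen-bond acceptor, yet it stays within the scatter of both isopentyloxy (a 1.3-fold higher number from compound 3 to compound 4 (0.10 log units; within the scatter)) and butoxy (a 1.6-fold higher number from compound 1 to compound 4 (0.22 log units; within the scatter)). The large gap to the short methoxy group also survives without that oxygen (an 18-fold lower number from compound 2 to compound 4 (1.24 log units; beyond the scatter)), so chain length, not the linking atom, separates these compounds. No measured evidence here accounts for this.

On these data alone, whether a chain longer than heptyl would keep this level remains open. So does the effect of an amine or a carboxylic acid at the end of the chain.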